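Methyl added to a phenyl ring on two related lactone cores

The source may hold more compounds than are shown below. What is called first, only, known or untested is meant among the compounds shown, and "the series" means these compounds.

Compound 1, `CC(=O)c1c(NNc2ccccc2)cc(C)oc1=O`, carries a phenylhydrazine group on a lactone core. In a functional assay on the whole organism for inhibition, with Rattus norvegicus as the target, read by paw edema, with a stated time of 3 h, at a dose of 50 mg/kg (on this read-out higher numbers stand for more inhibition at the one dose given (going by the name of the read-out) and lower numbers for less inhibition), compound 1 gives 55.6%. Compound 2, `CC(=O)c1c(NNc2ccc(C)cc2)cc(C)oc1=O`, differs from it in one place: methyl in place of hydrogen on an aromatic carbon. In this assay compound 2 gives 59.6%, and the step of a number 4 percentage points higher from compound 1 to compound 2 (within the scatter).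

Compound 3, `Cc1cc2nn(-c3ccccc3)c(C)c2c(=O)o1`, has a different core, in which the phenyl ring sits on a fused ring system; the difference between the two cores is not broken down here. In this assay compound 3 gives 52.5%, a number close to those of compound 1 and compound 2.

Compound 4, `Cc1ccc(-n2nc3cc(C)oc(=O)c3c2C)cc1`, has not yet been measured. It differs from compound 3 by methyl in place of hydrogen on an aromatic carbon, the same change that separates compound 2 from compound 1, at the same kind of place. Because that change gave only a number 4 percentage points higher from compound 1 to compound 2 (within the scatter), a step of similar size is expected here, a number 3.5 percentage points higher from compound 3 to compound 4 (within the scatter). Compound 4 is therefore expected to give about 56% in this assay, most likely between 46% and 66%.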

Compound 4, a percentage reported as inhibition, in the whole organism at one dose (the size of the read-out at that dose, not a potency): 54%
Estimate against measurement, compound 4: 2 percentage points above, and the stated range covers the measured number.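

In this assay, the step for methyl in place of hydrogen on an aromatic carbon of the phenyl ring is a number 1.5 percentage points higher from compound 3 to compound 4 (within the scatter). Within this small set, the change can therefore be carried from one core to the other without any detectable difference in its result: the same change on two cores in this assay, a number 4 percentage points higher (within the scatter) from compound 1 to compound 2 and a number 1.5 percentage points higher (within the scatter) from compound 3 to compound 4, 2.5 percentage points apart, within the scatter of two such steps. This does not show that methyl improves inhibition on either core, since neither step can be told apart from the scatter, and two pairs of compounds give no rule for other cores in the series.

The compounds shown leave open whether a chlorine atom, a methoxy group, a carboxylic acid or a longer chain at this same place would give a step that stands clear of the scatter, and whether such a step would then also carry across both cores. With only one dose and one stated time, they also leave open how the potency of these compounds compares.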